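Replacing the amide arm with a phenyltriazole

This account rests on a few compounds, and the source may have more. Where it says the series, first, only, none or still open, it means among the compounds named here.

The series shares one core and varies the arm on the phenolic oxygen. Compound 1 `COc1ccc(C[C@H]2COC(=O)[C@@H]2Cc2ccc(OCC(=O)N3CCCCC3)c(OC)c2)cc1OC` carries a piperidinyl amide on that arm; in an ADME assay on HeLa cells (Homo sapiens) for cytotoxicity, read by MTT assay (a higher number here means a weaker inhibitor, a lower number a stronger inhibitor), compound 1 gives 293000 nM. Compound 2 `COc1ccc(C[C@H]2COC(=O)[C@@H]2Cc2ccc(OC(=O)CCC(=O)N3CCCC3)c(OC)c2)cc1OC` gives 201000 nM in this assay, so that a 1.5-fold lower number from compound 1 to compound 2 (0.16 log units; within the scatter) and the two values stand together. Compound 3 `COc1ccc(C[C@H]2COC(=O)[C@@H]2Cc2ccc(OCC(=O)N3CCOCC3)c(OC)c2)cc1OC` gives only a limit, >= 600000 nM, in this assay. Against that limit the step of an at least 2.0-fold higher number from compound 1 to compound 3 (0.31 log units; beyond the scatter) and the step of an at least 2.9-fold higher number from compound 2 to compound 3 (0.47 log units; beyond the scatter) are both read, resting on (the limit of >= 600000 nM in this assay, at which 1 of the 3 values shown sits).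

Compound 4 `COc1ccc(C[C@H]2COC(=O)[C@@H]2Cc2ccc(OCc3cn(-c4ccccc4)nn3)c(OC)c2)cc1OC` is the next variation of compound 1. The change is 1-phenyl-1H-1,2,3-triazol-4-yl in place of (piperidin-1-yl)carbonyl on a saturated chain carbon bound to an oxygen on an aromatic ring. For the measured compounds named here, none of the measured steps alters the arm in this way: the two within-scatter or limit-bound steps all swap one saturated amine amide for another, whereas here the carbonyl and the amide nitrogen go and an aromatic pair of rings enters. Only the rough range of the series can guide the expectation, and a step of a 1.2-fold lower number from compound 1 to compound 4 (0.07 log units; within the scatter) is expected, that is, nothing that would clearly stand out from the scatter. Compound 4 is accordingly estimated at 250000 nM in this assay, with a range of 90000 nM to 600000 nM, and a limit rather than a number would not be surprising.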

Compound 4, half-maximal inhibitory concentration: 124000 nM
Compound 4: the middle estimate sits 2.0-fold (0.30 log units) above what was measured; the range from low to high includes it.
By their numbers in this assay, from the lowest: compounds 4, 2 and 1 (each within the scatter of the next, the first and the last beyond it). At a limit, above all of these: compound 3.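

For the compounds shown here, on the saturated chain carbon bound to an oxygen on an aromatic ring, 1-phenyl-1H-1,2,3-triazol-4-yl in place of (piperidin-1-yl)carbonyl gives the first lower number beyond the scatter in this assay: a 2.4-fold lower number from compound 1 to compound 4 (0.37 log units; beyond the scatter). The arm therefore need not keep its carbonyl or amide nitrogen for a number in this range, although the comparison with the other amide-bearing arm does not separate the two compounds: a 1.6-fold lower number from compound 2 to compound 4 (0.21 log units; within the scatter). As far as these compounds go, the step of an at least 4.8-fold lower number from compound 3 to compound 4 (0.68 log units; beyond the scatter) is read only against the limit of compound 3, so its true size stays unknown: the limit of >= 600000 nM in this assay, at which 1 of the 4 values shown sits.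

The compounds shown do not separate the contribution of the triazole from that of its phenyl ring, and a triazole carrying a methyl or benzyl group in place of that phenyl would bear on this directly. From the compounds shown here alone, a carboxylic acid or a primary amine at the end of the arm, or a longer chain between the phenolic oxygen and the triazole, also lies outside these compounds, so the reach of the step at this position remains open.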